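The source may hold more compounds than are shown below. What is called first, only, known or untested is meant among the compounds shown, and "the series" means these compounds.

Values so far in a toxicity assay on NIH3T3 cells (Mus musculus) for cytotoxicity, read by resazurin assay; a higher number here means that more compound is needed for the effect, a lower number that less compound is needed:
- Compound 1 `CNC(=O)c1ccc(NCc2cncn2Cc2ccc(-c3ccccc3)cc2N)cc1-c1ccccc1`: > 1000 nM, a limit
- Compound 2 `CNC(=O)c1ccc(NCc2cncn2Cc2ccc(-c3ccccc3)cc2)cc1-c1ccccc1`: > 1000 nM, a limit
- Compound 3 `Fc1ccc(Cn2cncc2CNc2ccc(-c3nc4ccccc4s3)c(-c3ccccc3)c2)c(F)c1`: > 1000 nM, a limit

Compound 1 has no numerical value, only a limit. Among the measured compounds shown here, the whole series so far comes down to the limit of > 1000 nM in this assay, at which 3 of the 3 values shown sit.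

Compound 4 `Nc1cc(-c2ccccc2)ccc1Cn1cncc1CNc1ccc(-c2nc3ccccc3s2)c(-c2ccccc2)c1` keeps the core of compound 1 and changes one group: 1,3-benzothiazol-2-yl in place of methylcarbamoyl on an aromatic carbon.

For the measured compounds named here, the only measured step is a step that the two limits leave unreadable from compound 1 to compound 2. It concerns hydrogen in place of amino, a different change, and gives no size to carry over. The closer guide is compound 3, which carries the same 1,3-benzothiazol-2-yl group and is itself a limit at > 1000 nM.

No clear direction can be read for this change in this assay, and the expected step is a step that the limit leaves unreadable from compound 1 to compound 4. Compound 4 is estimated at 2000 nM, with an expected range from 600 nM to 10000 nM. A further limit is the most likely report.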

Compound 4, half-maximal effective concentration: > 1000 nM
Compound 4 was reported as a limit (the forecaster's own chance of this, stated with the estimate: 75%); the middle value does not contradict the limit.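

In this assay, among the compounds shown here, compound 4 gives > 1000 nM, a limit, so no step from compound 1, also a limit, can be read. The compounds shown leave open what concentration gives the effect for any of them, as all stay at one limit: the limit of > 1000 nM in this assay, at which 4 of the 4 values shown sit.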